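Distal aryl swap on a shared imidazole-ethyl core

The source may report more compounds than this note shows. Statements on the series, on what has been measured and on what is new or still open speak of the compounds shown alone.

For the measured compounds named here, compound 3 `CCC(C)(C)Cc1c[nH]c(CCc2ccc(-c3cccc(C#N)n3)cc2)n1` gives 95 nM in a functional assay on HEK293 cells for agonist activity at Bombesin receptor subtype-3 (Homo sapiens), read by luminescence and calcium flux, with a stated time of 10 min (a higher number here means that more compound is needed for the effect, a lower number that less compound is needed), the lowest of the three numbers so far, though its neighbours sit within the scatter: compound 1 `CCC(C)(C)Cc1c[nH]c(CCc2ccc(-c3cnccn3)cc2)n1` gives 100 nM and compound 2 `CCC(C)(C)Cc1c[nH]c(CCc2ccc(N3CCCCC3)cc2)n1` gives 108 nM. The steps of a 1.1-fold lower number from compound 1 to compound 3 (0.02 log units; within the scatter) and a 1.1-fold lower number from compound 2 to compound 3 (0.06 log units; within the scatter) are both within the scatter, as is a 1.1-fold higher number from compound 1 to compound 2 (0.03 log units; within the scatter). Compound 4 `CCC(C)(C)Cc1c[nH]c(CCc2ccc(-c3ccc(F)cn3)cc2)n1` is not yet measured. It differs from compound 3 as follows: 5-fluoropyridin-2-yl in place of 6-cyanopyridin-2-yl on an aromatic carbon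

All three measured steps exchange the group at this same place, and none of them moved the number beyond the scatter, whether the group entering was pyrazin-2-yl, piperidin-1-yl or 6-cyanopyridin-2-yl. On that basis the step of a 1.1-fold higher number from compound 3 to compound 4 (0.02 log units; within the scatter) is expected to stay within the scatter, with no direction favoured. Compound 4 is estimated at 100 nM in this assay, with a range of 50 nM to 200 nM.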

Compound 4, half-maximal effective concentration: 97 nM
Compound 4: the middle estimate sits 1.0-fold (0.01 log units) above what was measured, and the stated range covers the measured number.
By their numbers in this assay, from the lowest: compounds 3, 4, 1 and 2 (each within the scatter of the next).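

At this position, on an aromatic carbon para to a large group, the step of a 1.0-fold higher number from compound 3 to compound 4 (0.01 log units; within the scatter) replaces the nitrile-bearing 6-cyanopyridin-2-yl with 5-fluoropyridin-2-yl, which shows that the nitrile is not needed to keep the number in this assay where it stands. The same holds against the other two groups, with a 1.1-fold lower number from compound 2 to compound 4 (0.05 log units; within the scatter) and a 1.0-fold lower number from compound 1 to compound 4 (0.01 log units; within the scatter), so four different groups at this place, the saturated piperidin-1-yl among them, now give numbers that cannot be told apart. Nothing on hand accounts for this lack of response.

As far as these compounds go, whether a carboxylic acid, a primary amine or a longer chain at this place would move the number beyond the scatter stays open. Also open, from the compounds shown here alone, is whether this insensitivity would persist with a change elsewhere on the shared core.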